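A few compounds are considered here, and "the series" means these few. Any claim that something is new, unique, unknown or untested is made for them only; others in the source may bear on it.

Measured in a functional assay on A-375 cells (Homo sapiens) for cytotoxicity, read by MTT assay, with a stated time of 72 h; a lower number here means a stronger inhibitor, a higher number a weaker inhibitor:
compound 1 `CN1CCN(CCCCCCn2c3c(c4ccccc42)C(=O)c2c[n+]([O-])c4ccccc4c2C3=O)CC1` gives 630 nM
compound 2 `CN1CCN(CCCCCn2c3c(c4ccccc42)C(=O)c2c[n+]([O-])c4ccccc4c2C3=O)CC1` gives 1710 nM
compound 3 `CN(C)CCCCn1c2c(c3ccccc31)C(=O)c1c[n+]([O-])c3ccccc3c1C2=O` gives 470 nM

Compound 3 holds the lowest of the three numbers. Its margin over compound 2 is clear, a 3.6-fold lower number from compound 2 to compound 3 (0.56 log units; beyond the scatter), whereas the step of a 1.3-fold lower number from compound 1 to compound 3 (0.13 log units; within the scatter) stays within the scatter, so compounds 1 and 3 cannot be ordered against each other.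

Compound 4 `CN1CCN(CCCCn2c3c(c4ccccc42)C(=O)c2c[n+]([O-])c4ccccc4c2C3=O)CC1` has not yet been measured in this assay. Its difference from compound 3 is 4-methylpiperazin-1-yl in place of dimethylamino on a saturated chain carbon, four bonds along the chain from an aromatic nitrogen. The chain is unchanged; the exchange sits on a saturated chain carbon, four bonds along the chain from an aromatic nitrogen.

The step that bears most directly on this is a 3.6-fold lower number from compound 2 to compound 3 (0.56 log units; beyond the scatter), the same exchange run in the opposite direction and cut one bond further out. Chain length is not indifferent among the methylpiperazine compounds, since a 2.7-fold higher number from compound 1 to compound 2 (0.43 log units; beyond the scatter) already lies beyond the scatter, so the transfer from the pentyl pair to the butyl pair carries some uncertainty. On balance the exchange is expected to raise the number, a modest step of a 2.3-fold higher number from compound 3 to compound 4 (0.37 log units; beyond the scatter). Compound 4 is therefore estimated at 1100 nM in this assay, with a range from 450 nM to 2700 nM.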

Compound 4, half-maximal inhibitory concentration: 30 nM
Beside the measured number, compound 4's estimate is 37-fold (1.56 log units) above it; measured number below the stated range.
By their numbers in this assay, from the lowest: compound 4; then compounds 3 and 1 (each within the scatter of the next); then compound 2.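

In this assay, the step to 4-methylpiperazin-1-yl at this position is a 16-fold lower number from compound 3 to compound 4 (1.19 log units; beyond the scatter), so the earlier 3.6-fold lower number from compound 2 to compound 3 (0.56 log units; beyond the scatter) gave no sound guide to this exchange on the shorter chain. Among the methylpiperazine compounds, chain length now weighs far more than a 2.7-fold higher number from compound 1 to compound 2 (0.43 log units; beyond the scatter) suggested: a 57-fold lower number from compound 2 to compound 4 (1.76 log units; beyond the scatter) and a 21-fold lower number from compound 1 to compound 4 (1.32 log units; beyond the scatter) place compound 4 clearly lowest of the series, although the number does not rise steadily with chain length, since compound 1, with the longest chain, lies below compound 2. No measurement is available to account for the gain from this exchange or for its dependence on chain length.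

The compounds shown leave open whether the gain is specific to 4-methylpiperazin-1-yl or would also appear with piperidin-1-yl, morpholin-4-yl or piperazin-1-yl on the same chain. They also leave open how a propyl chain bearing 4-methylpiperazin-1-yl would read, and whether dimethylamino on a pentyl or hexyl chain would follow the methylpiperazine compounds.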